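Triazole-linked furanone series: decyl chain removal

The source may hold more compounds than are shown below. What is called first, only, known or untested is meant among the compounds shown, and "the series" means these compounds.

Measured compounds:
compound 1 `O=C1O/C(=C\Cn2cc(-c3ccc(Br)cc3)nn2)C(OCc2ccccc2)=C1OCc1ccccc1` — > 100000 nM
compound 2 `O=C1O/C(=C\Cn2cc(-c3cc(F)cc(F)c3)nn2)C(OCc2ccccc2)=C1OCc1ccccc1` — "not active" (no number reported)
compound 3 `CCCCCCCCCCc1cn(C[C@H](O)[C@H]2OC(=O)C(OCc3ccccc3)=C2OCc2ccccc2)nn1` — 40300 nM

In a functional assay on CFPAC-1 cells (Homo sapiens) for antiproliferative activity, read by MTT assay, with a stated time of 72 h (a higher number here means a weaker inhibitor, a lower number a stronger inhibitor), compound 3 gives 40300 nM and is the only one of the three with a number. Compound 1 reaches only the limit > 100000 nM in this assay, a limit rather than a number, as the limit of > 100000 nM in this assay, at which 1 of the 3 values shown sits, records. Compound 2 is reported in this assay as "not active" (no number reported) without a number. No two of the three allow a measured step to be drawn, so compound 3 stands alone as the sole reference point, itself a weak inhibitor.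

Compound 4 `O=C1O[C@H]([C@@H](O)Cn2ccnn2)C(OCc2ccccc2)=C1OCc1ccccc1` differs from compound 3 by hydrogen in place of decyl on an aromatic carbon. Among the measured compounds shown here, the decyl chain is the one sizeable group that compound 3 carries beyond the shared core, and compound 3 is already weak; compound 4 is therefore expected to lose further ground rather than gain, with the step from compound 3 to compound 4 estimated at a 3.0-fold higher number from compound 3 to compound 4 (0.47 log units; beyond the scatter), beyond the scatter and toward weaker inhibition. Compound 4 is expected to give about 120000 nM in this assay, within 35000 nM to 400000 nM, with a real chance that only a limit is reported.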

Compound 4, half-maximal inhibitory concentration: > 100000 nM
Compound 4: only a limit was reported; the forecaster's own chance of this, stated with the estimate: 60%; the middle value is on the limit's open side.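

Among the compounds shown here, replacing decyl with hydrogen on the aromatic carbon of the five-membered aromatic ring gives the first measured step: an at least 2.4-fold higher number from compound 3 to compound 4 (0.39 log units; beyond the scatter) in this assay. For the compounds shown here, this shows that the decyl chain at this position contributes to the activity of compound 3, although that activity is itself modest, whereas the earlier compounds gave only one number and no step. The value of compound 4 is a limit and not a number, so the step fixes a direction and a minimum size but not the full loss, and the result adds a second compound at the same limit: the limit of > 100000 nM in this assay, at which 2 of the 4 values shown sit.

On these data alone, the shape of the dependence on chain length at this aromatic carbon remains open, since hydrogen and decyl are its only two points here, and a hexyl chain or a chain longer than decyl could fall on either side of compound 3, which gives 40300 nM. Also open, as far as these compounds go, is whether a chain ending in an amine or a carboxylic acid at the same place would keep any measurable activity.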